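Bromo for chloro at the assay limit

This account rests on a few compounds, and the source may have more. Where it says the series, first, only, none or still open, it means among the compounds named here.

- compound 1 `CN1C(=O)C(O)(Cc2nnn[nH]2)c2ccccc21`: 45500 nM
- compound 2 `CN1C(=O)C(O)(Cc2nnn[nH]2)c2cc(Cl)ccc21`: > 100000 nM (a limit)
- compound 3 `CN1C(=O)C(O)(Cc2nnn[nH]2)c2cc(Br)ccc21`: not yet measured

In a functional assay on PA-1 cells (Homo sapiens) for antiproliferative activity, read by MTT assay, with a stated time of 48 h (on this read-out higher numbers stand for weaker inhibition and lower numbers for stronger inhibition), compound 1 gives 45500 nM. Compound 2 sits at the limit of > 100000 nM in this assay, at which 1 of the 2 values shown sits, so its position is known only as a limit. The change to compound 3 is bromo in place of chloro on an aromatic carbon. Within the data shown here, one measured step bears on it: an at least 2.1-fold higher number from compound 1 to compound 2 (0.34 log units; beyond the scatter), with chloro in place of hydrogen on an aromatic carbon. Among the measured compounds shown here, no step from chloro to bromo has been measured, so no clear direction is expected in this assay, and no shift beyond the scatter is assumed. A second reading at the limit is quite likely. The estimated change is an at least 1.1-fold lower number from compound 2 to compound 3 (0.04 log units; that floor lies within the scatter). For compound 3 the expected value is 90000 nM, with an estimated range from 40000 nM to 200000 nM.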

Compound 3, half-maximal inhibitory concentration: > 100000 nM
Compound 3 ended at the assay's limit (the forecaster's own chance of this, stated with the estimate: 60%); middle value at least 1.1-fold (0.04 log units) away from the limit.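

In this assay, bromo in place of hydrogen on this aromatic carbon gives an at least 2.1-fold higher number from compound 1 to compound 3 (0.34 log units; beyond the scatter). The rise seen with chloro is therefore not confined to that one halogen: at this place, meta to a fused ring and para to a fused ring, compound 2 and compound 3 both read weaker than compound 1, and neither of the two goes against this. Compound 3 gives > 100000 nM, which is a limit and not a number, so the step between chloro and bromo cannot be read: the limit of > 100000 nM in this assay, at which 2 of the 3 values shown sit.

On these data alone, how far compound 2 and compound 3 lie past the limit, and in which order, remains open. Also open, as far as these compounds go, is whether an amine, a methoxy group or a carboxylic acid on this aromatic carbon would stay close to compound 1 or also reach the limit.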